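Dimethoxyphenyl in Place of Bromo-Methoxyphenyl: Expected Solubility

A few compounds are considered here, and "the series" means these few. Any claim that something is new, unique, unknown or untested is made for them only; others in the source may bear on it.

Of the compounds shown here, two sharing one core have been tested in a physicochemical assay for solubility, in phosphate buffer, measured as kinetic solubility, at pH 7.4; on this read-out lower numbers stand for lower solubility and higher numbers for higher solubility. For the measured compounds named here, compound 1 `Cc1cccc(Cl)c1-c1nc(CN2CCC(C(=O)NCCCN3CCC(C)(C)CC3)CC2)c(C)o1` is the first of them. In this assay compound 1 gives > 74 ug/mL, which is a limit of the assay rather than a number. Compound 2 `COc1cccc(Br)c1-c1nc(CN2CCC(C(=O)NCCCN3C[C@H](C)C[C@H](C)C3)CC2)c(C)o1` is the second. In this assay compound 2 gives > 83 ug/mL, again a limit and not a number. Going by the values given here, compound 2 thus stands at a limit, and the one other value shown is also a limit, so the two cannot be ranked against each other. Compound 3 `COc1ccc(-c2nc(CN3CCC(C(=O)NCCCN4C[C@H](C)C[C@H](C)C4)CC3)c(C)o2)cc1OC` has not yet been measured. It differs from compound 2 in a single place: 3,4-dimethoxyphenyl in place of 2-bromo-6-methoxyphenyl on an aromatic carbon. Among the compounds with values here, no measured step between two compounds exists to lean on. The expected step is a step that the limit leaves unreadable from compound 2 to compound 3 in this assay, which is none beyond the scatter, most likely ending once more at a limit. For compound 3 the estimate is 90 ug/mL, with a range from 40 ug/mL to 200 ug/mL.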

Compound 3, solubility: > 76 ug/mL
Compound 3 gave a limit, no number; the forecaster's own chance of this, stated with the estimate: 70%; the middle value does not contradict the limit.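

For the compounds shown here, compound 2 and compound 3 each give a limit and not a number in this assay, and no step between them can be read. The compounds shown leave open whether 3,4-dimethoxyphenyl in place of 2-bromo-6-methoxyphenyl changes this read-out at all.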